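Replacing the Oxetane on the Amide of Compound 3

This account rests on a few compounds, and the source may have more. Where it says the series, first, only, none or still open, it means among the compounds named here.

In a functional assay on MIA PaCa-2 cells (Homo sapiens) for inhibition, read by MTT assay, with a stated time of 7 days (on this read-out higher numbers stand for weaker inhibition and lower numbers for stronger inhibition), compound 3 (`CCN(CC)S(=O)(=O)c1ccc(S(=O)(=O)N2CCC[C@@H](C(=O)NC3COC3)C2)cc1`) gives 2340 nM as the highest number of the three measured. Compound 2 (`O=C([C@@H]1CCCN(S(=O)(=O)c2ccc(S(=O)(=O)C3COC3)cc2)C1)N1CCC(F)(F)CC1`) gives 110 nM and compound 1 (`O=C([C@@H]1CCCN(S(=O)(=O)c2ccc(S(=O)(=O)C3CCC3)cc2)C1)N1CCC(F)(F)CC1`) gives 9 nM on the same read-out. Compound 4 (`CCN(CC)S(=O)(=O)c1ccc(S(=O)(=O)N2CCC[C@@H](C(=O)N[C@H]3CC[C@@H](OC)CC3)C2)cc1`) differs from compound 3 by 4-methoxycyclohexyl in place of oxetan-3-yl on an amide-type nitrogen with 4-methoxycyclohexyl in place of oxetan-3-yl on an amide-type nitrogen. Among the measured compounds shown here, the one measured step involving oxetan-3-yl is large, a 12-fold higher number from compound 1 to compound 2 (1.09 log units; beyond the scatter) with oxetan-3-yl in place of cyclobutyl on a sulfonyl sulfur. It lies at another place in the structure, so it is only a loose guide, and a smaller move to a lower number is expected. For compound 4 the expected step is a 5.2-fold lower number from compound 3 to compound 4 (0.72 log units; beyond the scatter) in this direction. Compound 4 is estimated at 450 nM with 90 nM to 2200 nM as its expected range.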

Compound 4, half-maximal inhibitory concentration: 960 nM
Estimate against measurement, compound 4: 2.1-fold (0.33 log units) below; the measured number falls inside the stated range.
By their numbers in this assay, from the lowest: compound 1; then compound 2; then compound 4; then compound 3.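

Among the compounds shown here, on this amide-type nitrogen, where no step had been measured before, this assay now shows a modest change: a 2.4-fold lower number from compound 3 to compound 4 (0.39 log units; beyond the scatter). The exchange of oxetan-3-yl for 4-methoxycyclohexyl replaces a four-membered ring with a six-membered carbon ring and leaves the count of hydrogen-bond acceptors unchanged, so the step does not come with a change in that count. No measurement shown accounts for the step.

The compounds shown leave open whether the step follows the ring or the methoxy group. Plain cyclohexyl, or a 4-aminocyclohexyl group, on this nitrogen would separate the two.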